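The compounds below may be only part of what the source reports. "The series", "measured", "known", "first", "only" and "open" are said of these compounds alone.

In an assay on HEK293 cells for inhibition of Voltage-dependent T-type calcium channel subunit alpha-1G (Homo sapiens), read by fluorescence, tested at 10 uM (on this read-out lower numbers stand for less inhibition and higher numbers for more inhibition at the one concentration tested (going by the name of the read-out)), three compounds have been measured:

compound 1 `CCCc1nc(-c2ccccc2)c(CNCCN2CCN(c3ccc(Cl)cc3)CC2)o1`, 55.8%;
compound 2 `CCCc1nc(-c2ccccc2)c(CNCCN2CCN(c3cccc(C(F)(F)F)c3)CC2)o1`, 56.3%;
compound 3 `CCCc1nc(-c2ccccc2)c(CNCCN2CCN(c3ccc(C)cc3)CC2)o1`, 48.1%.

On these numbers compound 3 stands lowest of the three, but within the scatter of both others: a number 7.7 percentage points lower from compound 1 to compound 3 (within the scatter) and a number 8.2 percentage points lower from compound 2 to compound 3 (within the scatter). Compound 4 `CCCc1nc(-c2ccccc2)c(CNCCN2CCN(c3cccc(C)c3C)CC2)o1` has not been measured; it differs from compound 3 in one place: 2,3-dimethylphenyl in place of 4-methylphenyl on an amine nitrogen in a ring. Among the compounds with values here, the steps that bear on this change are those exchanging the group on an amine nitrogen in a ring among compounds 1, 2 and 3: a number 0.5 percentage points higher from compound 1 to compound 2 (within the scatter), a number 7.7 percentage points lower from compound 1 to compound 3 (within the scatter) and a number 8.2 percentage points lower from compound 2 to compound 3 (within the scatter). None moves the number beyond the scatter, so no step beyond the scatter is expected in this assay here either. For compound 4 the expected value is 50%, in the range 32% to 68%. That is an expected step of a number 1.9 percentage points higher from compound 3 to compound 4 (within the scatter).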

Compound 4, a percentage reported as inhibition, at one concentration (the size of the read-out at that concentration, not a potency): 66.7%
The estimate for compound 4 lay 16.7 percentage points below the measured number; the measured number falls inside the stated range.
By their numbers in this assay, from the lowest: compounds 3, 1 and 2 (each within the scatter of the next); then compound 4.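

In this assay, within the data shown here, a change on an amine nitrogen in a ring moves the number beyond the scatter for the first time: a number 18.6 percentage points higher from compound 3 to compound 4 (beyond the scatter) when 2,3-dimethylphenyl replaces 4-methylphenyl. The same group also stands clear of the other two, with a number 10.4 percentage points higher from compound 2 to compound 4 (beyond the scatter) against 3-(trifluoromethyl)phenyl and a number 10.9 percentage points higher from compound 1 to compound 4 (beyond the scatter) against 4-chlorophenyl. Nothing available explains this gain. The compounds shown leave open how an unsubstituted phenyl, a methoxyphenyl or a pyridyl group would read on this nitrogen.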